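Working notes: the 2-methylprop-1-en-1-yl amide step

This account rests on a few compounds, and the source may have more. Where it says the series, first, only, none or still open, it means among the compounds named here.

In a functional assay on A549 cells (Homo sapiens) for antiproliferative activity, read by MTT assay, with a stated time of 72 h (a higher number here means a weaker inhibitor, a lower number a stronger inhibitor), compound 1 (`CC(C)=CC(=O)Nc1cccc(Oc2nc(Nc3ccn(C)n3)nc3c2CSCC3)c1`) gives 44200 nM and compound 2 (`C/C=C/C(=O)Nc1cccc(Oc2nc(Nc3cccc(C#N)c3)nc3c2CSCC3)c1`) gives 17200 nM as the lower of the two numbers, with a gap beyond the usual scatter. Only these two readings exist so far for the series.

Compound 3 (`CC(C)=CC(=O)Nc1cccc(Oc2nc(Nc3cccc(C#N)c3)nc3c2CSCC3)c1`) is compound 2 with one change: 2-methylprop-1-en-1-yl in place of prop-1-en-1-yl on a carbonyl carbon. For the measured compounds named here, no measured pair of compounds isolates this change, so the evidence for the size of the step in this assay is thin. Compound 1 carries the same 2-methylprop-1-en-1-yl group and gives 44200 nM as its reading, which tilts the expectation slightly toward a higher number. The estimated step (a 1.3-fold higher number from compound 2 to compound 3 (0.11 log units; within the scatter)) is small and is expected to stay within the scatter. Compound 3 is estimated at 22000 nM with a range of 9000 nM to 50000 nM as the expected span of a measurement.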

Compound 3, half-maximal inhibitory concentration: 36900 nM
For compound 3 the middle estimate is 1.7-fold (0.22 log units) below the measured one, within the range that was stated.
By their numbers in this assay, from the lowest: compound 2; then compounds 3 and 1 (each within the scatter of the next).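

In this assay, the exchange of prop-1-en-1-yl for 2-methylprop-1-en-1-yl on the carbonyl carbon can now be read directly, with the rest of the molecule held constant, and it gives a 2.1-fold higher number from compound 2 to compound 3 (0.33 log units; beyond the scatter), a modest loss at this position that lies beyond the scatter. For the compounds shown here, with 2-methylprop-1-en-1-yl held on the carbonyl, putting 3-cyanophenyl in place of 1-methyl-1H-pyrazol-3-yl on the nitrogen gives a 1.2-fold lower number from compound 1 to compound 3 (0.08 log units; within the scatter), so of the two single changes available, only the one at the carbonyl carbon moves the number beyond the scatter. Nothing at hand gives a measured reason for the step at the carbonyl carbon.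

The compounds shown leave open whether that step carries over when 1-methyl-1H-pyrazol-3-yl sits on the nitrogen, and whether the two aryl groups also read alike with prop-1-en-1-yl on the carbonyl. Also open, going by these compounds, is how the number responds on the carbonyl carbon to a saturated propyl chain, or to a prop-1-en-1-yl group ending in a dimethylamino group.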